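Swapping the Ester Tail While Stability Sits at the Limit

A few compounds are considered here, and "the series" means these few. Any claim that something is new, unique, unknown or untested is made for them only; others in the source may bear on it.

Compound 1 `CC(=O)OCOC(=O)C1=C(S[C@@H]2CN[C@H](C(=O)Nc3cccc(C(=O)OCOC(C)=O)c3)C2)[C@H](C)[C@@H]2[C@@H]([C@@H](C)O)C(=O)N12` and compound 2 `CCC(CC)C(=O)OCOC(=O)C1=C(S[C@@H]2CN[C@H](C(=O)Nc3cccc(C(=O)O)c3)C2)[C@H](C)[C@@H]2[C@@H]([C@@H](C)O)C(=O)N12` were both tested in an ADME assay for metabolic stability, read by LC-MS, with a stated time of 3 h, at pH 6.5, tested at 50 uM; a higher number here means that more of the compound is left, a lower number that less of the compound is left. Compound 1 gives > 95%, which is a limit of the assay rather than a number. Compound 2 likewise gives > 95%, also a limit. Both measured compounds thus sit at the same edge, (the limit of > 95% in this assay, at which 2 of the 2 values shown sit), and compound 2 stands exactly there. Compound 3 `CCOC(=O)OCOC(=O)C1=C(S[C@@H]2CN[C@H](C(=O)Nc3cccc(C(=O)O)c3)C2)[C@H](C)[C@@H]2[C@@H]([C@@H](C)O)C(=O)N12` has not yet been measured; it differs from compound 2 by ethoxy in place of pentan-3-yl on a carbonyl carbon. Within the data shown here, no measured pair matches this change, so the expected step of a number at least 2 percentage points lower from compound 2 to compound 3 (that floor lies within the scatter) is small, staying within the usual scatter. Compound 3 is therefore expected to give about 93%, between 78% and 99%.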

Compound 3, percent of the compound remaining: > 95%
Compound 3: no number, only a limit (the forecaster's own chance of this, stated with the estimate: 70%); middle value at least 2 percentage points from the limit.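

Among these compounds, compound 2 and compound 3 both give only a limit, so no step between them can be read: the limit of > 95% in this assay, at which 3 of the 3 values shown sit. On these data alone, whether the three compounds truly differ in how much of each remains stays open.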